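Swapping the hydroxyethyl amide for a hydrazide

The source may hold more compounds than are shown below. What is called first, only, known or untested is meant among the compounds shown, and "the series" means these compounds.

The three measured compounds share one core and differ only in the group on a saturated chain carbon bound to an oxygen on an aromatic ring. Compound 1 `CCOc1ccc2cc(C(=O)NCCO)c(=O)oc2c1` carries a methyl there, and in a functional assay on HCT-116 cells (Homo sapiens) for cytotoxicity, read by MTT assay, with a stated time of 72 h (on this read-out lower numbers stand for stronger inhibition and higher numbers for weaker inhibition), compound 1 gives > 100000 nM, which is a limit of the assay rather than a number (the limit of > 100000 nM in this assay, at which 1 of the 3 values shown sits). Compound 2 `O=C(NCCO)c1cc2ccc(OCc3cccc(Br)c3)cc2oc1=O` carries a 3-bromophenyl, and in this assay compound 2 gives 30800 nM. Compound 3 `O=C(NCCO)c1cc2ccc(OCc3ccc([N+](=O)[O-])cc3)cc2oc1=O` carries a 4-nitrophenyl, and in this assay compound 3 gives 33400 nM. The steps are an at least 3.2-fold lower number from compound 1 to compound 2 (0.51 log units; beyond the scatter) and an at least 2.9-fold lower number from compound 1 to compound 3 (0.47 log units; beyond the scatter), while a 1.1-fold higher number from compound 2 to compound 3 (0.04 log units; within the scatter). Compound 3 thus holds the higher of the two numbers, with compound 2 nearest and the gap within the scatter.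

Compound 4 `NNC(=O)c1cc2ccc(OCc3ccc([N+](=O)[O-])cc3)cc2oc1=O` alters a different place: amino in place of 2-hydroxyethyl on an amide-type nitrogen. Within the data shown here, none of the measured steps touches the amide-type nitrogen, so they offer no guide to this change. A step of a 1.0-fold lower number from compound 3 to compound 4 (0.01 log units; within the scatter) is therefore expected, nothing beyond the scatter. For compound 4 in this assay the estimate is 33000 nM, with a range from 12000 nM to 90000 nM.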

Compound 4, half-maximal inhibitory concentration: > 100000 nM
Compound 4 was reported as a limit; the forecaster's own chance of this, stated with the estimate: 15%; middle value at least 3.0-fold (0.48 log units) away from the limit.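

Among these compounds, replacing 2-hydroxyethyl with amino on the amide-type nitrogen gives an at least 2.9-fold higher number from compound 3 to compound 4 (0.47 log units; beyond the scatter), so in this assay this position, which no earlier step touched, clearly affects the read-out. The 4-nitrophenyl group stays in place, so this loss of activity belongs to the change on the nitrogen alone, even though the group leaving and the group entering have the same counts of hydrogen-bond donors and acceptors. Compound 4 gives a limit of the assay rather than a number, so the true size of the step stays unknown, and it shares that limit with one other compound: the limit of > 100000 nM in this assay, at which 2 of the 4 values shown sit.

The compounds shown leave open whether a 3-hydroxypropyl chain or a plain methyl on this nitrogen would keep the activity of compound 3. They also leave open whether amino has the same effect when the 3-bromophenyl group of compound 2 is present.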